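Series notes: aryl substituent swap on the shared core

The compounds below may be only part of what the source reports. "The series", "measured", "known", "first", "only" and "open" are said of these compounds alone.

Compound 1 `Cc1ccc(Nc2nc(SCc3cn(CC(=O)NC(=O)Nc4ccccn4)nn3)nc(-c3ccc(C(C)C)cc3)c2C#N)cc1` carries methyl on one aromatic ring and isopropyl on the other. In a functional assay on MCF7 cells (Homo sapiens) for inhibition, read by MTT assay, with a stated time of 72 h (a higher number here means a weaker inhibitor, a lower number a stronger inhibitor), compound 1 gives only a limit of the assay, > 64000 nM, and no number. Compound 2 `CC(C)c1ccc(Nc2nc(SCc3cn(CC(=O)NC(=O)Nc4ccccn4)nn3)nc(-c3ccc(C(C)C)cc3)c2C#N)cc1` differs from compound 1 by isopropyl in place of methyl on an aromatic carbon; in this assay compound 2 gives 28600 nM. The step of an at least 2.2-fold lower number from compound 1 to compound 2 (0.34 log units; beyond the scatter) is the only measured one in the series, and it rests on (the limit of > 64000 nM in this assay, at which 1 of the 2 values shown sits).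

Compound 3 `Cc1ccc(Nc2nc(SCc3cn(CC(=O)NC(=O)Nc4ccccn4)nn3)nc(-c3ccc(Br)cc3)c2C#N)cc1` is not yet measured. It differs from compound 1 by bromo in place of isopropyl on an aromatic carbon. Going by the values given here, no measured step touches this ring; the single step known concerns the other ring, so it offers no guide to the size or direction of the change in this assay. Compound 1 sits at the limit of the assay, and a move beyond the scatter from there cannot be read off the data in hand.

For compound 3 the expected value in this assay is 60000 nM, within a range of 20000 nM to 160000 nM. The step this estimate implies, an at least 1.0-fold lower number from compound 1 to compound 3 (0.02 log units; that floor lies within the scatter), is expected to stay close to the scatter, with a fair chance that only a limit is reported again.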

Compound 3, half-maximal inhibitory concentration: 14400 nM
Compound 3: middle estimate off by 4.2-fold (0.62 log units), on the high side, and the stated range ends above it.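

The 4-isopropylphenyl to 4-bromophenyl change shows that this position, on an aromatic carbon para to a large group, also responds in this assay, with an at least 4.4-fold lower number from compound 1 to compound 3 (0.64 log units; beyond the scatter) as the measured step. Going by these compounds alone, until now, the only measured step lay on the other aromatic ring, an at least 2.2-fold lower number from compound 1 to compound 2 (0.34 log units; beyond the scatter), so isopropyl entering there and isopropyl leaving here now both go with a lower number, and isopropyl shows no single direction across the two rings. Compound 1 gives only a limit and not a number, so each step is a floor and not a size, and both rest on the same point: (the limit of > 64000 nM in this assay, at which 1 of the 3 values shown sits).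

The compounds shown leave open whether the two changes add up when bromo on this ring is paired with isopropyl on the other, a pairing that would differ from compound 2 and compound 3 in one place each. They also leave open whether the lower number follows bromine itself or the loss of the isopropyl group, a question that chloro, methyl or an amine at this position could help to separate.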